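Swapping a Sulfur-Containing Side Chain for Isopropyl

This account rests on a few compounds, and the source may have more. Where it says the series, first, only, none or still open, it means among the compounds named here.

Compound 1 `N=C(N)c1cccc(C(=O)N[C@@H](C(=O)NCc2ccccc2)c2ccccc2)c1`: 5400 nM
Compound 2 `N=C(N)c1cccc(C(=O)N[C@@H](C(=O)N2CCC(Cc3ccccc3)CC2)c2ccccc2)c1`: 650 nM
Compound 3 `CSCC[C@H](NC(=O)c1cccc(C(=N)N)c1)C(=O)NCC1CCC(CN)CC1`: 7900 nM

All three were tested in an assay on isolated protein for binding affinity to serine protease 1 (Homo sapiens); on this read-out lower numbers stand for stronger inhibition and higher numbers for weaker inhibition. Compound 3 carries the highest number of the three. Its value and that of compound 1 lie within the scatter of each other, so no order between them can be claimed, while compound 2 sits clearly lower, beyond the scatter.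

Compound 4 `CC(C)[C@H](NC(=O)c1cccc(C(=N)N)c1)C(=O)NCC1CCC(CN)CC1` differs from compound 3 in one place: isopropyl in place of 2-(methylsulfanyl)ethyl on a saturated chain carbon bound to an amide-type nitrogen and a carbonyl carbon. For the measured compounds named here, no measured pair shows an exchange of this kind, so the outcome cannot be read off from the data. The step is expected to be a 1.2-fold lower number from compound 3 to compound 4 (0.08 log units; within the scatter), a shift no larger than the scatter in either direction. Compound 4 is therefore expected to give about 6500 nM in this assay, with a range from 2000 nM to 20000 nM.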

Compound 4, inhibition constant: 12600 nM
Estimate against measurement, compound 4: 1.9-fold (0.29 log units) below, and the stated range covers the measured number.
By their numbers in this assay, from the lowest: compound 2; then compounds 1, 3 and 4 (each within the scatter of the next, the first and the last beyond it).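

In this assay the exchange of 2-(methylsulfanyl)ethyl for isopropyl on this saturated chain carbon gives a step that stays within the scatter (a 1.6-fold higher number from compound 3 to compound 4 (0.20 log units; within the scatter)). For the compounds shown here, this is the first direct reading at this place: the sulfur-containing chain can give way to isopropyl without a shift that can be told from repeat scatter. Nothing at hand offers an explanation for this result. From the compounds shown here alone, both groups are uncharged and without a ring, so it remains open whether a primary amine or a carboxylic acid here would shift the number beyond the scatter. The same question stands for a phenyl group, which would bring a ring to this carbon.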